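Swapping the Aryl Group on a Carbonyl Carbon

A few compounds are considered here, and "the series" means these few. Any claim that something is new, unique, unknown or untested is made for them only; others in the source may bear on it.

In a functional assay on HCT-116 cells (Homo sapiens) for inhibition, read by sulforhodamine B assay, with a stated time of 3 days (a lower number here means a stronger inhibitor, a higher number a weaker inhibitor), compound 1 `O=C1Nc2ccc(F)cc2/C1=C\C(=O)c1ccc(C2CCCCC2)cc1` gives 2520 nM and compound 2 `CN1CCN(c2cccc(N/C=C3\C(=O)Nc4ccc(NC(=O)c5cccc(F)c5)cc43)c2)CC1` gives 2740 nM. Among the compounds with values here, these two values lie within the scatter of each other, so compound 2 stands level with the only other measured compound, although the two structures differ widely.

Compound 3 `CN1CCN(c2cccc(N/C=C3\C(=O)Nc4ccc(NC(=O)c5c(Cl)cccc5Cl)cc43)c2)CC1` departs from compound 2 in one place, with 2,6-dichlorophenyl in place of 3-fluorophenyl on a carbonyl carbon. Within the data shown here, no measured pair of compounds shows what a change of this kind does, so the expectation rests only on compound 2 at 2740 nM. The expected change is small, a 1.2-fold lower number from compound 2 to compound 3 (0.10 log units; within the scatter), and it would not go beyond the scatter. In this assay, compound 3 is estimated at 2200 nM, with an expected range of 800 nM to 6000 nM.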

Compound 3, half-maximal inhibitory concentration: 2280 nM
Estimate against measurement, compound 3: 1.0-fold (0.02 log units) below, within the range that was stated.
By their numbers in this assay, from the lowest: compounds 3, 1 and 2 (each within the scatter of the next).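

In this assay, within the data shown here, the step of a 1.2-fold lower number from compound 2 to compound 3 (0.08 log units; within the scatter) is the first measured change at this position, on a carbonyl carbon whose other neighbour is an amide-type nitrogen. It shows that 3-fluorophenyl and 2,6-dichlorophenyl cannot be told apart here, so this exchange of one aryl group for the other, with the rest of the structure held constant, leaves the reading within the scatter. Nothing measured in the material shown bears on why the two groups read alike.

Among these compounds, this single step covers only two halogen-bearing phenyl groups, so it remains open whether a group of another kind at this position, such as a pyridine ring, a simple methyl or a phenyl carrying a carboxylic acid or an amine, would shift the number beyond the scatter. Compound 1 differs from the other two in more than one place and cannot settle this.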